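The compounds below may be only part of what the source reports. "The series", "measured", "known", "first", "only" and "open" are said of these compounds alone.

Measured compounds:
compound 1 `N#Cc1cccc(CO[C@@H]2C[C@@H]3[C@H]([C@]2(N)C(=O)O)[C@@]3(F)C(=O)O)c1` — 2.94 nM
compound 2 `N[C@]1(C(=O)O)[C@H]2[C@@H](C[C@H]1OCc1ccc(F)c(F)c1)[C@]2(F)C(=O)O` — 2.27 nM

Both compounds share a core and differ only in the aromatic group attached through the ether linkage. In an assay on CHO cells for binding affinity to metabotropic glutamate receptor 2 (Rattus norvegicus) (a lower number here means a stronger inhibitor, a higher number a weaker inhibitor), compound 1 gives 2.94 nM, and compound 2 gives 2.27 nM. Among the measured compounds shown here, compound 2 has the lowest of the two numbers, but its only neighbour is compound 1, and the step of a 1.3-fold lower number from compound 1 to compound 2 (0.11 log units; within the scatter) lies within the scatter, so the two cannot be told apart.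

Compound 3 `N[C@]1(C(=O)O)[C@H]2[C@@H](C[C@H]1OCc1cc(Cl)ccc1Cl)[C@]2(F)C(=O)O` continues this line: 2,5-dichlorophenyl in place of 3,4-difluorophenyl on a saturated chain carbon bound to an oxygen on a saturated carbon. For the measured compounds named here, the single step recorded so far, a 1.3-fold lower number from compound 1 to compound 2 (0.11 log units; within the scatter), exchanged one aromatic group for another at the same place and left this assay essentially unchanged. Going by the values given here, that is the only guide for a further exchange at this place, so the expectation is a step of a 1.5-fold higher number from compound 2 to compound 3 (0.19 log units; within the scatter) that does not reach beyond the scatter. Compound 3 is estimated at 3.5 nM, expected between 1.2 nM and 12 nM.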

Compound 3, inhibition constant: 11.8 nM
For compound 3 the middle estimate is 3.4-fold (0.53 log units) below the measured one, within the range that was stated.
By their numbers in this assay, from the lowest: compounds 2 and 1 (each within the scatter of the next); then compound 3.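

Unlike the earlier exchange at this place, this one registers in this assay: 2,5-dichlorophenyl gives a clear loss against 3,4-difluorophenyl (a 5.2-fold higher number from compound 2 to compound 3 (0.72 log units; beyond the scatter)) and against 3-cyanophenyl (a 4.0-fold higher number from compound 1 to compound 3 (0.60 log units; beyond the scatter)). The aromatic group on this ether is therefore not freely exchangeable, even though the two groups in the first of these steps match in heavy-atom count and in having no hydrogen-bond donors or acceptors. No measurement shown gives a reason for this loss.

Compound 2 and compound 3 differ in both the halogen and where it sits on the ring, and these two changes cannot be separated here. A 3,4-dichlorophenyl or 2,5-difluorophenyl group would pull them apart, while a phenyl ring carrying an amine remains an open question at this place.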